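Spirooxindole-quinoxaline series: acetamido in place of amino

A few compounds are considered here, and "the series" means these few. Any claim that something is new, unique, unknown or untested is made for them only; others in the source may bear on it.

Measured so far:
compound 1 `N#CC1=C(N)Oc2c(c3nc4ccccc4nc3c3ccccc23)C12C(=O)N(Cc1cnnn1-c1ccccc1Br)c1ccccc12` — a functional assay on HCT-116 cells (Homo sapiens) for antiproliferative activity, read by MTT assay, with a stated time of 48 h; on this read-out lower numbers stand for stronger inhibition and higher numbers for weaker inhibition: > 50000 nM
compound 2 `N#CC1=C(N)Oc2c(c3nc4ccccc4nc3c3ccccc23)C12C(=O)N(Cc1cnnn1-c1ccc(N)cc1)c1ccccc12` — this assay: 45200 nM

Compound 1 gives only a limit of the assay, (the limit of > 50000 nM in this assay, at which 1 of the 2 values shown sits), and no number. Compound 2 gives the only number shown, 45200 nM, so within what has been measured it stands alone; the step of an at least 1.1-fold lower number from compound 1 to compound 2 (0.04 log units; that floor lies within the scatter) carries a 4-aminophenyl in place of the 2-bromophenyl and sits at a floor that lies within the scatter.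

Compound 3 `CC(=O)Nc1ccc(-n2nncc2CN2C(=O)C3(C(C#N)=C(N)Oc4c3c3nc5ccccc5nc3c3ccccc43)c3ccccc32)cc1` differs from compound 2 by acetyl in place of hydrogen on a nitrogen on an aromatic ring. For the measured compounds named here, no measured step touches this change; the one measured step, at a floor within the scatter, says nothing about its direction. Compound 3 is therefore expected to sit close to compound 2 in this assay, with a step of a 1.1-fold higher number from compound 2 to compound 3 (0.04 log units; within the scatter) of no size beyond the scatter. The estimate for compound 3 is 50000 nM, between 20000 nM and 120000 nM, with a real chance that only a limit is reported.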

Compound 3, half-maximal inhibitory concentration: > 50000 nM
Compound 3 was reported as a limit; the forecaster's own chance of this, stated with the estimate: 55%; the middle value lies on the limit itself.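

In this assay compound 3 gives > 50000 nM, which is a limit of the assay and not a number. Amino to acetamido on the 4-aminophenyl therefore yields no measurable potency in this assay; the change gives only an at least 1.1-fold higher number from compound 2 to compound 3 (0.04 log units; that floor lies within the scatter), and the step between the two compounds that carry limits cannot be read. Compound 2 remains the only compound here with a number, and the series now sits largely at the assay ceiling: the limit of > 50000 nM in this assay, at which 2 of the 3 values shown sit.

As far as these compounds go, how far compound 3 truly lies from compound 2 stays open, since the floor fixes neither the size of the step nor anything beyond its lower bound. Also open, from the compounds shown here alone, is whether a dimethylamine, a carboxylic acid or a longer acyl chain such as butanoyl at this place on the phenyl ring would give a number clearly apart from that of compound 2.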